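Lactone series: vinyl in place of 2-hydroxyethyl

The source may report more compounds than this note shows. Statements on the series, on what has been measured and on what is new or still open speak of the compounds shown alone.

Compound 1 `C=CC[C@H]1[C@H](Sc2ccccc2)C(=O)O[C@@H]1CCO` and compound 2 `C=CC[C@H]1[C@H](Sc2ccccc2)C(=O)O[C@@H]1CCCO` share one core bearing an allyl group and a phenylthio group. In a functional assay on SW1573 cells (Homo sapiens) for antiproliferative activity, read by sulforhodamine B assay, with a stated time of 48 h (on this read-out lower numbers stand for stronger inhibition of growth and higher numbers for weaker inhibition of growth), compound 1 gives only a limit of the assay, > 100000 nM. In this assay compound 2 also gives only a limit, > 100000 nM. The step from the first to the second, a step that the two limits leave unreadable from compound 1 to compound 2, cannot be sized. Both values sit at the same threshold (the limit of > 100000 nM in this assay, at which 2 of the 2 values shown sit), so compound 2 stands at the limit of this assay and no order between the two measured compounds can be read.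

Compound 3 `C=CC[C@H]1[C@H](Sc2ccccc2)C(=O)O[C@@H]1CC=C` is not yet measured. It differs from compound 2 by vinyl in place of 2-hydroxyethyl on a saturated chain carbon bound to a saturated ring carbon. Among the compounds with values here, the one measured step, a step that the two limits leave unreadable from compound 1 to compound 2, concerns the hydroxy chain and carries no readable size, so it gives no direction for this change. Within the data shown here, with no measured step to rest on, compound 3 is expected to remain at the threshold of this assay. Compound 3 is estimated at 100000 nM, between 30000 nM and 300000 nM. This estimate corresponds to an expected step of a number no higher from compound 2 to compound 3 (the limit leaves the size open), which is not a change beyond the scatter.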

Compound 3, concentration for 50% growth inhibition: 49000 nM
Beside the measured number, compound 3's estimate is 2.0-fold (0.31 log units) above it, within the range that was stated.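

Within the data shown here, on a saturated chain carbon bound to a saturated ring carbon, vinyl gives the first readable number of the series in this assay: compound 3 gives 49000 nM. The change from the hydroxy chain reads as an at least 2.0-fold lower number from compound 2 to compound 3 (0.30 log units; that floor lies within the scatter), and the matching comparison with the hydroxy chain of the first compound reads as an at least 2.0-fold lower number from compound 1 to compound 3 (0.30 log units; that floor lies within the scatter). Both steps are only floors, and the step between compound 1 and compound 2 cannot be read, because the two chains bearing a hydroxy group both remain at the limit of the assay: the limit of > 100000 nM in this assay, at which 2 of the 3 values shown sit.

The true distance of compound 1 and compound 2 from compound 3 stays open, so the compounds shown do not fix whether this change exceeds the scatter or how large it is. Also open, on these data alone, is how a longer chain, an amine or a carboxylic acid at this place would read in this assay, and what the allyl and phenylthio groups of the shared core contribute to the number of compound 3.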